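The source may hold more compounds than are shown below. What is called first, only, known or untested is meant among the compounds shown, and "the series" means these compounds.

Compound 1 `CCCSc1nnc(Cc2ccccc2Oc2ccccc2)[nH]1` gives 128% in a functional assay on the whole organism (strain NMRI) with Mus musculus as the target, with a stated time of 60 min, at a dose of 5 mg/kg by the intraperitoneal route; on this read-out lower numbers stand for a weaker effect and higher numbers for a stronger effect at the one dose given. Compound 2 `c1ccc(CSc2nnc(Cc3ccccc3Oc3ccccc3)[nH]2)cc1` gives 129%. Compound 3 `CCCSc1nnc(Cc2ccc(Cl)cc2Oc2ccccc2F)[nH]1` gives 119%.

Compound 1 and compound 2 share a core and differ in one place: phenyl in place of ethyl on a saturated chain carbon bound to a sulfur. That change gave a number 1 percentage points higher from compound 1 to compound 2 (within the scatter), so the two numbers cannot be told apart here. Compound 3 carries a different core, and the difference between the two cores is not broken down here; its value and that of compound 2 lie close together as well.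

Compound 4 `Fc1ccccc1Oc1cc(Cl)ccc1Cc1nnc(SCc2ccccc2)[nH]1` has the core of compound 3 and differs from it in one place: phenyl in place of ethyl on a saturated chain carbon bound to a sulfur. The place is the same, word for word, as in the change from compound 1 to compound 2, so this is the same change made on the other core. Among the measured compounds shown here, the only guide is that earlier pair, where the change moved the read-out by a number 1 percentage points higher from compound 1 to compound 2 (within the scatter). On that basis the expected step is a number 1 percentage points higher from compound 3 to compound 4 (within the scatter), a step within the scatter. Compound 4 is therefore expected to give about 120%, estimated between 105% and 135%.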

Compound 4, a percentage reported as activity, at one dose (the size of the read-out at that dose, not a potency): 166%
Compound 4: middle estimate off by 46 percentage points, on the low side; the measured number lies above the stated range.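

On the core of compound 3, putting phenyl in place of ethyl on a saturated chain carbon bound to a sulfur (propylsulfanyl to benzylsulfanyl) gave a number 47 percentage points higher from compound 3 to compound 4 (beyond the scatter) in this assay at the one dose given. The size of this change's effect therefore did not carry over from one core to the other, so a step read on one core was a poor guide to the step on the other: the same change on two cores in this assay, a number 1 percentage points higher (within the scatter) from compound 1 to compound 2 and a number 47 percentage points higher (beyond the scatter) from compound 3 to compound 4, 46 percentage points apart, beyond the scatter of two such steps. This shows that the result of the change depends on the core it is made on, but two pairs do not show which part of the core makes the difference, nor how the change would behave on a third core.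

As far as these compounds go, it remains open whether a longer chain such as butyl, or an amine, in place of the phenyl on the core of compound 3 would keep the higher number. The compounds shown also leave open which of the differences between the two cores goes with the larger step.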